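From chloro to hydrogen on an inactive compound

A few compounds are considered here, and "the series" means these few. Any claim that something is new, unique, unknown or untested is made for them only; others in the source may bear on it.

Compound 1 `COC1=CC(=O)C(C)=C([S@@+]([O-])c2ccc(C)cc2)C1=O` gives 5500 nM
Compound 2 `Cc1ccc([S@+]([O-])C2=C(Cl)C(=O)C=CC2=O)cc1` gives "not active" (no number reported)

Both compounds were tested in a functional assay on Hep 3B2 cells (Homo sapiens) for inhibition, read by sulforhodamine B assay, with a stated time of 72 h (on this read-out higher numbers stand for weaker inhibition and lower numbers for stronger inhibition), where compound 1 yields a number. Compound 2 is reported as "not active" (no number reported) and has no single number, so it cannot be placed on the scale. The unmeasured compound 3 `Cc1ccc([S@+]([O-])C2=CC(=O)C=CC2=O)cc1` comes next. The change is hydrogen in place of chloro on a double-bonded ring carbon, with hydrogen in place of chloro on a double-bonded ring carbon. Among the measured compounds shown here, no measured pair shows this change, so the data give no size for the step. For the measured compounds named here, a modest step toward stronger inhibition is expected in this assay, enough to yield a number, with compound 1 at 5500 nM as the only numerical guide. Compound 3 is estimated at 6000 nM, with an expected range from 1500 nM to 25000 nM.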

Compound 3, half-maximal inhibitory concentration: 17400 nM
Estimate against measurement, compound 3: 2.9-fold (0.46 log units) below, within the range that was stated.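

Among the compounds shown here, compound 2 has no number in this assay, so no step to compound 3 can be read. These compounds leave open how large the change from chloro to hydrogen on a double-bonded ring carbon is on this read-out. No available evidence bears on this result.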